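This account rests on a few compounds, and the source may have more. Where it says the series, first, only, none or still open, it means among the compounds named here.

Measured compounds:
compound 1, `CCOC(=O)C1=C(C)NC(C)=C(C(=O)OC)C1c1csc(-c2ccc(Cl)cc2)n1`, 22000 nM;
compound 2, `COC(=O)C1=C(C)NC(C)=C(C(=O)OC(C)(C)C)C1c1csc(-c2ccc(Cl)cc2)n1`, 46000 nM;
compound 3, `COC(=O)C1=C(C)NC(C)=C(C(=O)OCCc2ccccc2)C1c1csc(-c2ccc(Cl)cc2)n1`, 10200 nM.

In an assay on isolated protein for antagonist activity at Voltage-dependent L-type calcium channel subunit alpha-1C (Cavia porcellus), with a stated time of 15 min (on this read-out higher numbers stand for weaker inhibition and lower numbers for stronger inhibition), compound 1 stands second highest of the three numbers; compound 2 sits nearest, a 2.1-fold higher number from compound 1 to compound 2 (0.32 log units; beyond the scatter), while compound 3 sits furthest, a 2.2-fold lower number from compound 1 to compound 3 (0.33 log units; beyond the scatter). Compound 4, `CCOC(=O)C1=C(C)NC(C)=C(C(=O)OC(C)c2ccccc2)C1c1csc(-c2ccc(Cl)cc2)n1`, is the next compound, differing from compound 1 by 1-phenylethyl in place of methyl on an oxygen next to a carbonyl group.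

For the measured compounds named here, three measured steps bear on this change. Adding a phenyl on the chain gave a 2.2-fold lower number from compound 1 to compound 3 (0.33 log units; beyond the scatter), and exchanging tert-butyl for phenethyl gave a 4.5-fold lower number from compound 2 to compound 3 (0.65 log units; beyond the scatter), both toward stronger inhibition. Against that, branching the ester in a 2.1-fold higher number from compound 1 to compound 2 (0.32 log units; beyond the scatter) went the other way. The incoming 1-phenylethyl combines a phenyl with a branched carbon on the oxygen, so the two tendencies partly cancel. A modest step toward a lower number is therefore expected for compound 4, a 1.6-fold lower number from compound 1 to compound 4 (0.20 log units; within the scatter), with the range kept wide. Compound 4 is estimated at 14000 nM, between 6000 nM and 35000 nM.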

Compound 4, half-maximal inhibitory concentration: 13800 nM
For compound 4 the middle estimate is 1.0-fold (0.01 log units) above the measured one, within the range that was stated.
By their numbers in this assay, from the lowest: compounds 3, 4 and 1 (each within the scatter of the next, the first and the last beyond it); then compound 2.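

In this assay, putting 1-phenylethyl in place of methyl on an oxygen next to a carbonyl group gave a 1.6-fold lower number from compound 1 to compound 4 (0.20 log units; within the scatter). This shows that, on the core of compound 1, this position accepts a group of 8 heavy atoms carrying a six-membered aromatic ring with a branched carbon on the oxygen, and the number does not separate from that of compound 1. No measurement at hand accounts for this result.

The compounds shown leave open whether a longer chain ending in phenyl, or a chain bearing an amine or a carboxylic acid, on this oxygen would move the number beyond the scatter. They also leave open whether 1-phenylethyl would give a similar result in place of the ethyl on the other ester.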